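Benzyl amide variation on the trans-aminocyclohexyl series

The source may hold more compounds than are shown below. What is called first, only, known or untested is meant among the compounds shown, and "the series" means these compounds.

Among the compounds with values here, compound 2 `N[C@H]1CC[C@H](Nc2c(C(=O)NCc3ccc(Cl)cc3Cl)nc(Br)c3cccnc23)CC1` is the only member of this set with a numerical result: in a functional assay on HCT-116 cells (Homo sapiens) for cytotoxicity, read by MTT assay, with a stated time of 72 h (a lower number here means a stronger inhibitor, a higher number a weaker inhibitor), compound 2 gives 6000 nM. Compound 3 `O=C(NCCCNc1c(C(=O)NCc2ccc(F)cc2)nc(Br)c2cccnc12)c1ccccc1` reaches only a limit in this assay, > 10000 nM, which is the limit of > 10000 nM in this assay, at which 1 of the 3 values shown sits. Compound 1 `COC(=O)c1nc(Br)c2cccnc2c1N[C@H]1CC[C@H](N)CC1`, the methyl ester, stands at "not determined" (no result reported) in this assay. Compound 4 `N[C@H]1CC[C@H](Nc2c(C(=O)NCc3ccccc3)nc(Br)c3cccnc23)CC1` is not yet measured; it differs from compound 2 by phenyl in place of 2,4-dichlorophenyl on a saturated chain carbon bound to an amide-type nitrogen. Within the data shown here, no step between two measured compounds is available to calibrate this change. The step expected in this assay, a 1.5-fold higher number from compound 2 to compound 4 (0.18 log units; within the scatter), is small, at most slightly toward weaker inhibition, and may not exceed the scatter. Compound 4 is estimated at 9000 nM, between 3000 nM and 25000 nM, with a real chance that only a limit is reported.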

Compound 4, half-maximal inhibitory concentration: 7000 nM
For compound 4 the middle estimate is 1.3-fold (0.11 log units) above the measured one; low and high end bracket the measured number.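

In this assay, within the data shown here, phenyl in place of 2,4-dichlorophenyl gives a 1.2-fold higher number from compound 2 to compound 4 (0.07 log units; within the scatter), the first step that can be read. On a saturated chain carbon bound to an amide-type nitrogen, the two chlorines therefore make no difference that can be told from the scatter in this assay. Nothing shown accounts for this result.

Still open, on these data alone, is whether an amine or a carboxylic acid on the phenyl ring, or a longer chain in place of benzyl, would shift the cytotoxicity beyond the scatter.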